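Swapping a methoxy ring for a fluorophenyl on the cinnamide arm

The source may report more compounds than this note shows. Statements on the series, on what has been measured and on what is new or still open speak of the compounds shown alone.

Of the compounds shown here, three sharing one core have been tested in a functional assay on ME-180 cells (Homo sapiens) for cytotoxicity, read by MTT assay, with a stated time of 72 h; on this read-out higher numbers stand for weaker inhibition and lower numbers for stronger inhibition. Compound 1, with the structure `COc1ccc(C(=O)c2cc(OC)c(OC)c(OC)c2)cc1NC(=O)/C=C/c1cc(OC)c(OC)c(OC)c1`, gives 2100 nM. Compound 2, with the structure `COc1ccc(C(=O)c2cc(OC)c(OC)c(OC)c2)cc1NC(=O)/C=C/c1ccc(OC)c(OC)c1`, gives 8900 nM. Compound 3, with the structure `COc1cccc(/C=C/C(=O)Nc2cc(C(=O)c3cc(OC)c(OC)c(OC)c3)ccc2OC)c1`, gives 4300 nM, which places it second highest of the three numbers: the step of a 2.0-fold higher number from compound 1 to compound 3 (0.31 log units; beyond the scatter) separates it from compound 1, and the step of a 2.1-fold lower number from compound 2 to compound 3 (0.32 log units; beyond the scatter) from compound 2.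

Compound 4, with the structure `COc1ccc(C(=O)c2cc(OC)c(OC)c(OC)c2)cc1NC(=O)/C=C/c1ccc(F)cc1`, differs from compound 3 only at the far end of the cinnamide arm: 4-fluorophenyl in place of 3-methoxyphenyl on a double-bonded chain carbon bound to a double-bonded chain carbon. Among the compounds with values here, no measured step removes the last methoxy group or brings in a fluorine, so the bearing steps are only indirect. They show that trimming methoxy groups from this ring moved the number in both directions, as in a 4.2-fold higher number from compound 1 to compound 2 (0.63 log units; beyond the scatter) and a 2.1-fold lower number from compound 2 to compound 3 (0.32 log units; beyond the scatter), each modest. Losing the remaining hydrogen-bond acceptor here is therefore expected to cost a little, and the step of a 1.4-fold higher number from compound 3 to compound 4 (0.14 log units; within the scatter) is estimated to lie around the edge of the scatter. Compound 4 is expected to give 6000 nM, within a range of 2500 nM to 15000 nM.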

Compound 4, half-maximal inhibitory concentration: 300 nM
The estimate for compound 4 lay 20-fold (1.30 log units) above the measured number; measured number below the stated range.
By their numbers in this assay, from the lowest: compound 4; then compound 1; then compound 3; then compound 2.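

In this assay the ring at the end of the cinnamide arm proves able to move the number much further than the earlier methoxy changes did, since 4-fluorophenyl in place of 3-methoxyphenyl gives a 14-fold lower number from compound 3 to compound 4 (1.16 log units; beyond the scatter) and 4-fluorophenyl in place of 3,4-dimethoxyphenyl gives a 30-fold lower number from compound 2 to compound 4 (1.47 log units; beyond the scatter) as large steps. Against 3,4,5-trimethoxyphenyl the same kind of change gives a 7.0-fold lower number from compound 1 to compound 4 (0.85 log units; beyond the scatter) as a modest step, so all three methoxy-bearing rings end with higher numbers than 4-fluorophenyl. Within the data shown here, no measured information here explains why this change lowers the number so far.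

Still open, on these data alone, is whether the fluorine, the absence of any methoxy group, or the place of the substituent on the ring accounts for the drop. A plain phenyl, 3-fluorophenyl or 4-chlorophenyl at this position would help to separate those readings.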